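Changing the Group on an Aromatic Nitrogen at the Limit

The compounds below may be only part of what the source reports. "The series", "measured", "known", "first", "only" and "open" are said of these compounds alone.

Compound 2 `CN1C(=S)[C@@H](NC(=O)c2nc(Cc3ccccc3)n(CC3CCOC3)n2)COc2ccccc21` offers no exact number as a starting point. In a toxicity assay on HT-29 cells (Homo sapiens) for cytotoxicity (on this read-out higher numbers stand for lower toxicity in this test and lower numbers for higher toxicity in this test), compound 2 gives > 100000 nM, which is a limit and not a number. Compound 1 `CC(C)Cn1nc(C(=O)N[C@H]2COc3ccccc3N(C)C2=S)nc1Cc1ccccc1` gives > 100000 nM, also a limit. Both values shown fall at the same place: the limit of > 100000 nM in this assay, at which 2 of the 2 values shown sit.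

Compound 3 `CN1C(=S)[C@@H](NC(=O)c2nc(Cc3ccccc3)n(C3CCN(C(=O)OC(C)(C)C)C3)n2)COc2ccccc21` differs from compound 2 in the group on an aromatic nitrogen: a group of 12 heavy atoms (9 carbon, 1 nitrogen, 2 oxygen; one five-membered non-aromatic ring with 1 hetero atom) in place of a group of 6 heavy atoms (5 carbon, 1 oxygen; one five-membered non-aromatic ring with 1 hetero atom), on an aromatic nitrogen. The entering group also brings 1 double bond outside aromatic rings.

Going by the values given here, only one measured step bears on this change, and it involves the group on the same nitrogen: a step that the two limits leave unreadable from compound 1 to compound 2. That step has no readable size, so it cannot show how far a new group might shift the result. Neither compound at its two ends gave a number, however, so no step beyond the usual scatter is expected in this assay, and no direction is predicted. The expected step is a number no higher from compound 2 to compound 3 (the limit leaves the size open). The estimated value for compound 3 is 100000 nM, with an expected range from 40000 nM to 200000 nM.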

Compound 3, half-maximal cytotoxic concentration: > 100000 nM
Compound 3 was reported as a limit; the forecaster's own chance of this, stated with the estimate: 85%; the middle value lies on the limit itself.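

Compound 3 also gives a limit and not a number, so the steps among compound 1, compound 2 and compound 3 cannot be read, and all three sit at one place: the limit of > 100000 nM in this assay, at which 3 of the 3 values shown sit.

From the compounds shown here alone, whether the group on the aromatic nitrogen changes the result in this assay at all, and in which direction, stays open.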